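The source may report more compounds than this note shows. Statements on the series, on what has been measured and on what is new or still open speak of the compounds shown alone.

Compound 1 `CC(C)C(Nc1nnc[nH]1)c1ccc(-c2ccc3cccc(F)c3c2)[nH]c1=O` and compound 2 `CC(C)[C@H](C[C@H]1CCNC1=O)c1ccc(-c2ccc3cccc(F)c3c2)[nH]c1=O` share the same core and differ from each other in more than one place, so their two values are simply set side by side. In an ADME assay on microsomes from liver (Homo sapiens) for metabolic stability (on this read-out lower numbers stand for a shorter-lived compound and higher numbers for a longer-lived compound), compound 1 gives > 3 h, and this is a limit of the assay rather than a number. Compound 1 therefore stands at the limit of > 3 h in this assay, at which 1 of the 2 values shown sits. Compound 2 gives 0.257 h in this assay. Compound 3 `Cc1nc(C(c2ccc(-c3ccc4cccc(F)c4c3)[nH]c2=O)C(C)C)[nH]c1C` is the not yet measured relative of compound 1, with 4,5-dimethyl-1H-imidazol-2-yl in place of (4H-1,2,4-triazol-3-yl)amino on a saturated chain carbon bound to an aromatic carbon and a saturated chain carbon. Within the data shown here, no measured pair shows a change of this kind, so the expected step from compound 1 to compound 3 rests on the starting point alone: a moderate shortening of half-life is expected, an at least 2.0-fold lower number from compound 1 to compound 3 (0.30 log units; that floor lies within the scatter), somewhat beyond the usual scatter. For compound 3 the half-life in this assay is estimated at 1.5 h, expected to fall between 0.5 h and 3.5 h.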

Compound 3, half-life: 0.268 h
Estimate against measurement, compound 3: 5.6-fold (0.75 log units) above; measured number below the stated range.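

In this assay, placing 4,5-dimethyl-1H-imidazol-2-yl in place of (4H-1,2,4-triazol-3-yl)amino on this saturated chain carbon gives an at least 11-fold lower number from compound 1 to compound 3 (1.04 log units; beyond the scatter). Among these compounds, this is the first comparison here that changes one place only, and it shows that half-life depends strongly on the group at this carbon. The step is a minimum, since compound 1 carries a limit of the assay and not a number: the limit of > 3 h in this assay, at which 1 of the 3 values shown sits.

The swap alters the ring's hetero atoms, adds two methyl groups and removes the amino link all at once, and these compounds do not show which of those changes matters. From the compounds shown here alone, how a plain 1H-imidazol-2-yl without the methyl groups, or a 4H-1,2,4-triazol-3-yl attached directly to this carbon, would behave remains open.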